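The source may hold more compounds than are shown below. What is called first, only, known or untested is meant among the compounds shown, and "the series" means these compounds.

Compound 1 `N#CC1=C(N)Oc2c(c3nc4ccccc4nc3c3ccccc23)C12C(=O)N(Cc1cnnn1-c1cccc(Br)c1)c1ccccc12` — in an ADME assay on L02 cells (Homo sapiens) for antiproliferative activity, read by MTT assay, with a stated time of 48 h (on this read-out higher numbers stand for weaker inhibition and lower numbers for stronger inhibition), compound 1 gives > 50000 nM, a limit of the assay rather than a number.
Compound 2 `Cc1ccc(C)c(-n2nncc2CN2C(=O)C3(C(C#N)=C(N)Oc4c3c3nc5ccccc5nc3c3ccccc43)c3ccccc32)c1` — in this assay compound 2 gives > 50000 nM, likewise a limit.

Both measured compounds therefore sit at the limit of > 50000 nM in this assay, at which 2 of the 2 values shown sit, and the step that the two limits leave unreadable from compound 1 to compound 2 cannot be read in size or direction. Compound 2 thus stands at the limit, with no number beyond it.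

Compound 3 `Cc1ccc(-n2nncc2CN2C(=O)C3(C(C#N)=C(N)Oc4c3c3nc5ccccc5nc3c3ccccc43)c3ccccc32)cc1Cl` differs from compound 2 by 3-chloro-4-methylphenyl in place of 2,5-dimethylphenyl on an aromatic nitrogen. Going by the values given here, the one measured step that bears on this kind of swap on the same aromatic nitrogen, a step that the two limits leave unreadable from compound 1 to compound 2, gives no readable size, so no shift beyond the scatter can be expected in this assay from this change. Compound 3 is estimated at 50000 nM, with a range of 20000 nM to 200000 nM. The expected step is a number no higher from compound 2 to compound 3 (the limit leaves the size open), most likely reported again only as a limit.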

Compound 3, half-maximal inhibitory concentration: > 50000 nM
Compound 3 gave a limit, no number (the forecaster's own chance of this, stated with the estimate: 80%); the middle value lies on the limit itself.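

Compound 1, compound 2 and compound 3 give only limits, not numbers, so no step among them can be read in size or direction: the limit of > 50000 nM in this assay, at which 3 of the 3 values shown sit.

The compounds shown leave open whether swapping the substituted phenyl group on the aromatic nitrogen changes inhibition in this assay at all.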